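The source may hold more compounds than are shown below. What is called first, only, known or untested is meant among the compounds shown, and "the series" means these compounds.

Compound 1 `CCCCCC(CCO)n1cnc2c(N(C)C)ncnc21`: > 50000 nM, a limit
Compound 2 `CCCCCCC(CCO)n1cnc2c(N(C)C)ncnc21`: > 50000 nM, a limit
Compound 3 `CCCCCCCCCCCC(CCO)n1cnc2c(Cl)ncnc21`: 5290 nM

Within the data shown here, in a functional assay on SW480 cells (Homo sapiens) for antiproliferative activity, read by MTT assay, with a stated time of 48 h (a higher number here means a weaker inhibitor, a lower number a stronger inhibitor), compound 3 gives 5290 nM, the only true number so far. The other two results are limits, not numbers: the limit of > 50000 nM in this assay, at which 2 of the 3 values shown sit.

Compound 4 `CCCCCCCCCCCC(CCO)n1cnc2c(N(C)C)ncnc21` keeps the long chain of compound 3 but has dimethylamino in place of chloro on an aromatic carbon. Among the measured compounds shown here, no measured pair shows this exchange directly. For the measured compounds named here, the one measured step, a step that the two limits leave unreadable from compound 1 to compound 2, is a change in the chain and cannot be read, so it offers no size to carry over.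

The closest clue comes from the group itself. Compound 2 also carries dimethylamino, and its > 50000 nM is a limit. Its chain is shorter than that of compound 4, however, so this clue is weak. The expectation therefore rests mainly on compound 3 at 5290 nM, with a modest shift towards a weaker inhibitor in this assay and wide uncertainty. The expected change is a 1.7-fold higher number from compound 3 to compound 4 (0.23 log units; within the scatter). For compound 4 the estimate is 9000 nM, with an expected range of 2500 nM to 40000 nM.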

Compound 4, half-maximal inhibitory concentration: 11800 nM
Compound 4: middle estimate off by 1.3-fold (0.12 log units), on the low side; low and high end bracket the measured number.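

In this assay, the exchange of chloro for dimethylamino on this aromatic carbon now has a readable size: a 2.2-fold higher number from compound 3 to compound 4 (0.35 log units; beyond the scatter). With the long chain held the same, the chloro compound is therefore the stronger inhibitor of this pair, and the step shows that dimethylamino does not rule out a measurable value once the chain is long. Among these compounds, with dimethylamino held the same, the chain can also be compared for the first time, as the longer chain gives an at least 4.2-fold lower number from compound 2 to compound 4 (0.62 log units; beyond the scatter) and an at least 4.2-fold lower number from compound 1 to compound 4 (0.62 log units; beyond the scatter). Compound 1 and compound 2 each carry a limit and not a number, so these two steps give only a minimum size: the limit of > 50000 nM in this assay, at which 2 of the 4 values shown sit.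

Going by these compounds, it remains open how other groups on the same aromatic carbon, such as methoxy or a simple primary amine, would compare with chloro and dimethylamino. Also open, on these data alone, are how a chain longer than that of compound 4 would read, whether chloro would give a number on the shorter chains of compound 1 and compound 2, and what a carboxylic acid in place of the chain's hydroxyl end would do.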